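The compounds below may be only part of what the source reports. "The series", "measured", "known", "first", "only" and "open" are said of these compounds alone.

Of the compounds shown here, two in this set have been measured in a physicochemical assay for solubility, at pH 7.4; on this read-out lower numbers stand for lower solubility and higher numbers for higher solubility. Compound 1 `O=C1CCCCN1c1cccc(C(=O)N(c2ncccc2Cl)[C@@H]2CCCNC2)c1` gives > 973000 nM in this assay, and that figure is a limit of the measurement rather than a number. Compound 2 `CN1CCN(c2cnc(NCc3c(F)ccc4c3CCO4)n3cnnc23)C1=O` gives 641000 nM in this assay. Compound 2 therefore holds the only numerical result shown, while the one further value, that of compound 1, is a limit (the limit of > 973000 nM in this assay, at which 1 of the 2 values shown sits). For the measured compounds named here, no pair of measured compounds differs in a single place, so no measured step is available to lean on.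

Compound 3 `CN1CCCN(c2cnc(NCc3c(F)ccc4c3CCO4)n3cnnc23)C1=O` has not been measured. It differs from compound 2 by a group of 8 heavy atoms (5 carbon, 2 nitrogen, 1 oxygen; one six-membered non-aromatic ring with 2 hetero atoms) in place of a group of 7 heavy atoms (4 carbon, 2 nitrogen, 1 oxygen; one five-membered non-aromatic ring with 2 hetero atoms), on an aromatic carbon. The change is modest in size and adds one carbon to a non-aromatic ring while keeping the same count of hetero atoms, donors and acceptors. Without a measured step of this kind, the expectation is a step from compound 2 to compound 3 of a 1.3-fold lower number from compound 2 to compound 3 (0.11 log units; within the scatter) in this assay, small and within the usual scatter, or slightly downward. Compound 3 is accordingly expected to give about 500000 nM in this assay, within a range of 200000 nM to 1000000 nM.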

Compound 3, solubility: 153000 nM
The estimate for compound 3 lay 3.3-fold (0.51 log units) above the measured number; the measured number lies below the stated range.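

In this assay, putting the six-membered non-aromatic ring in place of the 3-methyl-2-oxoimidazolidin-1-yl group, on the same aromatic carbon of the shared core, gives a 4.2-fold lower number from compound 2 to compound 3 (0.62 log units; beyond the scatter). For the compounds shown here, this is the first measured step at this position, and it shows that the read-out here is not indifferent to the change: the step lies beyond the scatter although the two groups have the same count of hetero atoms, hydrogen-bond donors and acceptors, and neither carries a net charge. Going by these compounds alone, nothing measured in this set accounts for the size of the step, since the only evidence available concerns a limit reached by a compound that differs from these two in more than one place.

The compounds shown leave open whether a morpholine ring or an open-chain dimethylamino group on this aromatic carbon would read nearer to compound 2 or to compound 3. They also leave open whether the same exchange of rings would give a step of like size and direction on another core, as this is a single step at a single position.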